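Aryl urea series: 4-chlorophenyl in place of 3-chlorophenyl

A few compounds are considered here, and "the series" means these few. Any claim that something is new, unique, unknown or untested is made for them only; others in the source may bear on it.

Measured so far in an ADME assay for permeability, using PAMPA, at pH 7.4; a higher number here means that the compound crosses the layer faster, a lower number that the compound crosses the layer more slowly:

compound 1 `Cc1cc(NC(=O)Nc2ccc(C)c(Cl)c2)c2ccccc2n1`: 262 10^-6 cm/s
compound 2 `Cc1cc(NC(=O)Nc2cccc(Cl)c2)c2ccccc2n1`: 566 10^-6 cm/s
compound 3 `COC(=O)c1cccc(NC(=O)Nc2cc(C)nc3ccccc23)c1`: 746 10^-6 cm/s

Compound 2 stands second highest of the three numbers in this assay; its nearest neighbour is compound 3, its furthest compound 1. Two steps are known. The step of a 2.2-fold higher number from compound 1 to compound 2 (0.33 log units; beyond the scatter) is modest and beyond the scatter, with hydrogen in place of methyl on an aromatic carbon. The step of a 1.3-fold higher number from compound 2 to compound 3 (0.12 log units; within the scatter) is within the scatter, with methoxycarbonyl in place of chloro on an aromatic carbon.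

The next compound is compound 4 `Cc1cc(NC(=O)Nc2ccc(Cl)cc2)c2ccccc2n1`. The change from compound 2 is 4-chlorophenyl in place of 3-chlorophenyl on an amide-type nitrogen. Neither measured step is a true counterpart of this change: both alter which groups sit on the aryl ring, while here the same groups are kept and only joined differently. What the two steps show is that changes on this aryl ring have moved the number in this assay by modest amounts at most, and compound 2 and compound 3 sit within the scatter of each other despite a larger swap. The expectation for compound 4 is therefore no step beyond the scatter, a 1.1-fold lower number from compound 2 to compound 4 (0.04 log units; within the scatter). Compound 4 is estimated at 520 10^-6 cm/s, with a range from 280 10^-6 cm/s to 1000 10^-6 cm/s.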

Compound 4, apparent permeability: 537 10^-6 cm/s
Compound 4: middle estimate off by 1.0-fold (0.01 log units), on the low side, within the range that was stated.
By their numbers in this assay, from the lowest: compound 1; then compounds 4, 2 and 3 (each within the scatter of the next).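

Read in this assay, 4-chlorophenyl in place of 3-chlorophenyl on the amide-type nitrogen gives a 1.1-fold lower number from compound 2 to compound 4 (0.02 log units; within the scatter), which leaves compound 2 and compound 4 within the scatter of each other. Among these compounds, this is the first step here that keeps the same atoms on this nitrogen and only joins them differently, and for these two chlorophenyl groups the difference does not separate the compounds, whereas the one step beyond the scatter so far, a 2.2-fold higher number from compound 1 to compound 2 (0.33 log units; beyond the scatter), alters which groups sit on the ring. No measurement at hand bears on why the two chlorophenyl compounds read alike.

Open, as far as these compounds go, is whether an amine or a carboxylic acid on this aryl ring would stay within the scatter of compound 2 in this assay, or would shift the number as far as the methyl of compound 1 does. Equally open, from the compounds shown here alone, is whether this result for chloro carries over to other groups rearranged in the same way, such as methoxycarbonyl, and whether a longer chain in place of the methyl on the shared core would matter more than changes on the aryl ring.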